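A few compounds are considered here, and "the series" means these few. Any claim that something is new, unique, unknown or untested is made for them only; others in the source may bear on it.

The three measured compounds share one core and differ only in the aryl group on the double-bonded chain carbon. Compound 1 `O=C1/C(=C\c2ccc(F)cc2)c2ccccc2N1c1c(Cl)cccc1Cl`, the fluoro compound, in a functional assay on B16-F10 cells (Homo sapiens) for cytotoxicity against B16-F10 (Mus musculus), read by MTT assay, with a stated time of 72 h (on this read-out higher numbers stand for an effect only at larger amounts of compound and lower numbers for an effect already at smaller amounts), gives 38 ug/mL. Compound 2 `O=C1/C(=C\c2cccc(Oc3ccccc3)c2)c2ccccc2N1c1c(Cl)cccc1Cl`, the phenoxy compound, in this assay gives only a limit of the assay, > 100 ug/mL. Compound 3 `CN(C)c1ccc(/C=C2\C(=O)N(c3c(Cl)cccc3Cl)c3ccccc32)cc1`, the dimethylamino compound, in this assay also gives a limit and no number, > 100 ug/mL. Compound 3 thus sits at the limit of > 100 ug/mL in this assay, at which 2 of the 3 values shown sit. Among the compounds with values here, the one step that ties it to a number is an at least 2.6-fold higher number from compound 1 to compound 3 (0.42 log units; beyond the scatter), which carried the compound from a measurable value up to the limit.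

Compound 4 `O=C1/C(=C\c2cccc(Br)c2)c2ccccc2N1c1c(Cl)cccc1Cl` has not been measured in this assay. It differs from compound 3 by 3-bromophenyl in place of 4-(dimethylamino)phenyl on a double-bonded chain carbon bound to a double-bonded ring carbon. Within the data shown here, the only measured step that bears on this change is an at least 2.6-fold higher number from compound 1 to compound 3 (0.42 log units; beyond the scatter), read in reverse: replacing a halogen by dimethylamino raised the number past the limit, and compound 4 again carries a halogen, bromo, in place of dimethylamino. On this basis the expected step is an at least 2.0-fold lower number from compound 3 to compound 4 (0.30 log units; that floor lies within the scatter), a return toward the number of compound 1, though it rests on a single pair and the halogen now sits at a different ring position. Compound 4 is therefore estimated in this assay at 50 ug/mL, with a range from 20 ug/mL to 120 ug/mL.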

Compound 4, concentration for half-maximal effect: 8 ug/mL
Beside the measured number, compound 4's estimate is 6.3-fold (0.80 log units) above it; the whole stated range lies above it.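

Compound 4 shows that this aryl position can do better than the fluoro compound and not merely return toward it: a 4.8-fold lower number from compound 1 to compound 4 (0.68 log units; beyond the scatter). Within the data shown here, the earlier compounds gave only one number, so they showed a loss from that number and no gain, whereas bromo now opens a wide span at this place: an at least 12-fold lower number from compound 3 to compound 4 (1.09 log units; beyond the scatter), and for bromo in place of phenoxy on an aromatic carbon, an at least 12-fold lower number from compound 2 to compound 4 (1.09 log units; beyond the scatter). These last two steps are minimum sizes, as compound 2 and compound 3 each stand at a limit of the assay and not at a number: the limit of > 100 ug/mL in this assay, at which 2 of the 4 values shown sit.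

Compound 1 and compound 4 differ in both the halogen and where it sits on the aryl ring, so the compounds shown cannot say whether bromo itself or its place carries the gain. They also leave open whether a chloro, a methyl or a carboxylic acid at this place would follow bromo or fall to the limit with phenoxy and dimethylamino.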